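This account rests on a few compounds, and the source may have more. Where it says the series, first, only, none or still open, it means among the compounds named here.

Measured in a functional assay on Hep 3B2 cells (Homo sapiens) for inhibition, read by MTT assay, with a stated time of 72 h; on this read-out higher numbers stand for weaker inhibition and lower numbers for stronger inhibition:
- compound 1 `Nc1ncnc2c1c(-c1cnc3[nH]ccc3c1)nn2CCCCCCCCC(=O)NO` gives 8390 nM
- compound 2 `Nc1nc2cc(-c3nn(CCCCC(=O)NO)c4ncnc(N)c34)ccc2o1` gives 33700 nM

Compound 2 holds the higher of the two numbers, and the gap to compound 1 lies beyond the scatter. Compound 3 `Nc1nc2cc(-c3nn(CCCCCCCCC(=O)NO)c4ncnc(N)c34)ccc2o1` extends the chain of compound 2, with this change: 4-(hydroxycarbamoyl)butyl in place of hydroxycarbamoyl on a saturated chain carbon, four bonds along the chain from an aromatic nitrogen (4-(hydroxycarbamoyl)butyl in place of hydroxycarbamoyl). For the measured compounds named here, no measured pair isolates this change, so its size is uncertain. A step to a lower number, beyond the scatter, is expected in this assay and would be a 3.7-fold lower number from compound 2 to compound 3 (0.57 log units; beyond the scatter) as estimated here. Compound 3 is expected at 9000 nM (estimated range 2500 nM to 30000 nM).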

Compound 3, half-maximal inhibitory concentration: 8890 nM
The estimate for compound 3 lay 1.0-fold (0.01 log units) above the measured number; the range from low to high includes it.
By their numbers in this assay, from the lowest: compounds 1 and 3 (each within the scatter of the next); then compound 2.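

In this assay, 4-(hydroxycarbamoyl)butyl in place of hydroxycarbamoyl on a saturated chain carbon gives a 3.8-fold lower number from compound 2 to compound 3 (0.58 log units; beyond the scatter), so chain length at this position moves the number beyond the scatter. With the longer chain held, exchanging the aromatic group on the shared core gives a 1.1-fold higher number from compound 1 to compound 3 (0.03 log units; within the scatter), so the two aromatic groups are not separated at this chain length. Nothing on hand accounts for the chain step.

From the compounds shown here alone, whether a still longer chain continues this step remains open. So does the effect of a carboxylic acid in place of the terminal hydroxycarbamoyl.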